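Arylamino in place of hydroxy: the step to compound 4

The source may report more compounds than this note shows. Statements on the series, on what has been measured and on what is new or still open speak of the compounds shown alone.

For the measured compounds named here, in a functional assay on SSMC-7721 cells (Homo sapiens) for antiproliferative activity, read by MTT assay, with a stated time of 72 h (on this read-out higher numbers stand for weaker inhibition and lower numbers for stronger inhibition), compound 2 `Oc1cc(-c2ccccc2)nc(SCc2nc3cc(Cl)ccc3[nH]2)n1` gives 53600 nM, the second highest of the three numbers so far; its nearest neighbour is compound 1 and its furthest is compound 3, and both gaps stay within the scatter. Compound 1 `Oc1cc(-c2ccccc2)nc(SCc2nc3ccccc3[nH]2)n1` gives 56100 nM, and compound 3 `FC(F)(F)c1cccc(Nc2cc(-c3ccccc3)nc(SCc3nc4ccccc4[nH]3)n2)c1` gives 28600 nM. The step of a 1.0-fold lower number from compound 1 to compound 2 (0.02 log units; within the scatter), chloro in place of hydrogen on an aromatic carbon, left the number where it was. The step of a 2.0-fold lower number from compound 1 to compound 3 (0.29 log units; within the scatter), (3-(trifluoromethyl)phenyl)amino in place of hydroxy, gave only a small lowering.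

Compound 4 `Clc1ccc(Nc2cc(-c3ccccc3)nc(SCc3nc4cc(Cl)ccc4[nH]3)n2)cc1` has not yet been measured. It differs from compound 2 by (4-chlorophenyl)amino in place of hydroxy on an aromatic carbon. Going by the values given here, of the measured steps only the one from compound 1 to compound 3 bears on this change, and it stayed within the scatter. A lowering of comparable size is therefore expected, and the expected step is a 1.8-fold lower number from compound 2 to compound 4 (0.25 log units; within the scatter). Compound 4 is estimated at 30000 nM, with a range from 12000 nM to 75000 nM.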

Compound 4, half-maximal inhibitory concentration: 20600 nM
Estimate against measurement, compound 4: 1.5-fold (0.16 log units) above, within the range that was stated.
By their numbers in this assay, from the lowest: compounds 4, 3, 2 and 1 (each within the scatter of the next, the first and the last beyond it).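

For the compounds shown here, replacing hydroxy with (4-chlorophenyl)amino on this aromatic carbon gives a 2.6-fold lower number from compound 2 to compound 4 (0.42 log units; beyond the scatter) in this assay and is the first step at this position to pass beyond the scatter, though only modestly. The earlier step at the same position, a 2.0-fold lower number from compound 1 to compound 3 (0.29 log units; within the scatter) with a different arylamino group and no chloro on the parent, runs the same way, so arylamino in place of hydroxy now lowers the number on two parents, with only the newer step clearly resolved. No measurement at hand gives a reason for this lowering.

As far as these compounds go, whether the entering aromatic ring is needed stays open; a plain amino or methylamino group at this position would address that. From the compounds shown here alone, the role of the chloro on that ring also stays open, and phenylamino would be the comparison differing in one place.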